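The source may hold more compounds than are shown below. What is called first, only, known or untested is meant among the compounds shown, and "the series" means these compounds.

In a functional assay on Huh-5-2 cells (Homo sapiens) for cytotoxicity, read by microscopy (on this read-out lower numbers stand for higher toxicity in this test and higher numbers for lower toxicity in this test), compound 1 (`CC(=O)OC[C@H]1O[C@@H](n2c(=S)[nH]c3cncnc32)[C@H](OC(C)=O)[C@@H]1OC(C)=O`) returns > 122000 nM as its reading, which is a limit and not a number. Compound 2 (`CC(=O)OC[C@H]1O[C@@H](n2c(SCc3cc4ccccc4oc3=O)nc3cncnc32)[C@H](O)[C@@H]1O`) gives 8700 nM in this assay and compound 3 (`CC(=O)OC[C@H]1O[C@@H](n2c(SCc3cc4cc(F)ccc4oc3=O)nc3cncnc32)[C@H](O)[C@@H]1O`) gives 8600 nM there, so compound 3 stands level with compound 2 within the scatter of the measurement.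

Compound 4 (`CC(=O)OC[C@H]1O[C@@H](n2c(SCc3cc4cc(Br)ccc4oc3=O)nc3cncnc32)[C@H](O)[C@@H]1O`) has not been measured yet. Compared with compound 3, it carries bromo in place of fluoro on an aromatic carbon and the rest of the structure stays the same.

Going by the values given here, only one measured step bears on this swap: fluoro in place of hydrogen on an aromatic carbon, which gave a 1.0-fold lower number from compound 2 to compound 3 (0.01 log units; within the scatter) and left the reading where it was. That single pair is a thin guide, and it involves fluoro, not bromo, so the range should stay generous. Taking that step as the guide, no step beyond the scatter is expected in this assay and the estimate amounts to a 1.1-fold lower number from compound 3 to compound 4 (0.03 log units; within the scatter) at its middle. For compound 4 the expected value is 8000 nM with an estimated range from 4000 nM to 16000 nM in this test.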

Compound 4, half-maximal cytotoxic concentration: 31000 nM
The estimate for compound 4 lay 3.9-fold (0.59 log units) below the measured number; the measured number lies above the stated range.
By their numbers in this assay, from the lowest: compounds 3 and 2 (each within the scatter of the next); then compound 4. At a limit, above all of these: compound 1.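

Earlier, fluoro in place of hydrogen on this aromatic carbon gave a 1.0-fold lower number from compound 2 to compound 3 (0.01 log units; within the scatter) in this assay and so offered no sign that the reading depends on what this carbon carries. Bromo shows that it can: bromo in place of fluoro gives a 3.6-fold higher number from compound 3 to compound 4 (0.56 log units; beyond the scatter) and bromo in place of hydrogen gives a 3.6-fold higher number from compound 2 to compound 4 (0.55 log units; beyond the scatter) in the same test. The two steps agree, and among hydrogen, fluoro and bromo at this place only bromo goes with a higher number, which here stands for lower toxicity in this test, but nothing measured here accounts for this difference.

Going by these compounds, whether chloro on the same aromatic carbon would read like fluoro or like bromo stays open, and so does the reading with a larger or very different group there, such as a methoxy group, an amine or a carboxylic acid. On these data alone, it also stays open whether bromo on another carbon of this six-membered aromatic ring would give a step of the same size.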